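From Carboxy to Methoxycarbonyl on the Shared Core

This account rests on a few compounds, and the source may have more. Where it says the series, first, only, none or still open, it means among the compounds named here.

Measured in a functional assay on SN12C cells (Homo sapiens) for antiproliferative activity; on this read-out higher numbers stand for weaker inhibition of growth and lower numbers for stronger inhibition of growth:
Compound 1 `CCCCCCNC(=O)c1cc(C#Cc2cc(OC)ccc2OC)ccc1OC`: > 100000 nM
Compound 2 `COc1ccc(OC)c(C#Cc2ccc(OC)c(C(=O)O)c2)c1`: 38200 nM

Compound 1 reads > 100000 nM, which is a limit and not a number. Within the data shown here, compound 2, at 38200 nM, therefore holds the only true number in this assay. Compound 3 `COC(=O)c1cc(C#Cc2cc(OC)ccc2OC)ccc1OC` differs from compound 2 by methyl in place of hydrogen on an oxygen next to a carbonyl group, with methyl in place of hydrogen on an oxygen next to a carbonyl group. Among the measured compounds shown here, the sole measured change on that carbonyl carbon is an at least 2.6-fold lower number from compound 1 to compound 2 (0.41 log units; beyond the scatter), and it is open-ended, resting on (the limit of > 100000 nM in this assay, at which 1 of the 2 values shown sits). That step exchanged a different group, so no clear step beyond the scatter is expected here, in either direction. The estimated step is a 1.3-fold lower number from compound 2 to compound 3 (0.10 log units; within the scatter). For compound 3 the expected value is 30000 nM, with an estimated range of 6000 nM to 100000 nM.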

Compound 3, concentration for 50% growth inhibition: 37900 nM
Compound 3: middle estimate off by 1.3-fold (0.10 log units), on the low side; measured number inside the range.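

In this assay, the exchange of hydroxy for methoxy on this carbonyl carbon gives a 1.0-fold lower number from compound 2 to compound 3 (0.00 log units; within the scatter), so carboxy and methoxycarbonyl cannot be told apart here. Methoxy in place of hexylamino on the same carbon gives an at least 2.6-fold lower number from compound 1 to compound 3 (0.42 log units; beyond the scatter), the same picture as compound 2 showed. That step is open-ended, as the value of compound 1 is a limit and not a number: the limit of > 100000 nM in this assay, at which 1 of the 3 values shown sits.

Going by these compounds, whether ethoxycarbonyl, or an amide with a shorter chain such as butylamino, would read like compound 3 or like compound 1 stays open.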